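Replacing Oxanyl with Phenyl on a Pyrazolotriazine Amine

A few compounds are considered here, and "the series" means these few. Any claim that something is new, unique, unknown or untested is made for them only; others in the source may bear on it.

Compound 1 `Cc1cc(-c2cnn3c(NCC4CCOCC4)nc(NC4CCOCC4)nc23)ccc1C(=O)NC1CC1`: 780 nM
Compound 2 `CN(c1nc(NCC2CCOCC2)n2ncc(-c3ccc(C(=O)NC4CC4)c(F)c3)c2n1)C1CCCCC1`: "not determined" (no result reported)

In a functional assay on OVCAR-3 cells (Homo sapiens) for antiproliferative activity (on this read-out higher numbers stand for weaker inhibition of growth and lower numbers for stronger inhibition of growth), compound 1 gives 780 nM, the only number shown, so compound 1 stands alone on this read-out; for compound 2 the result is "not determined" (no result reported). Compound 3 `Cc1cc(-c2cnn3c(NCC4CCOCC4)nc(Nc4ccccc4)nc23)ccc1C(=O)NC1CC1` differs from compound 1 by phenyl in place of oxan-4-yl on a nitrogen on an aromatic ring. Within the data shown here, no measured step covers this change. Compound 3 is expected to stay close to compound 1, with a step of a 1.0-fold higher number from compound 1 to compound 3 (0.01 log units; within the scatter) that is estimated not to go beyond the usual scatter. In this assay compound 3 is estimated at 800 nM, within a range from 250 nM to 2500 nM.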

Compound 3, concentration for 50% growth inhibition: 1700 nM
The estimate for compound 3 lay 2.1-fold (0.33 log units) below the measured number; low and high end bracket the measured number.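

Phenyl in place of oxan-4-yl on a nitrogen on an aromatic ring brings a 2.2-fold higher number from compound 1 to compound 3 (0.34 log units; beyond the scatter) in this assay. Among these compounds, this gives the first measured step at this position: the ring change weakens growth inhibition modestly, beyond the scatter, but compound 3 remains active in the same range as compound 1. Compound 2 has no reported result, so steps to it cannot be read.

As far as these compounds go, whether a pyridinyl ring or a piperidin-4-yl group here would sit closer to oxan-4-yl or to phenyl stays open. Nothing available explains the step.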